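A few compounds are considered here, and "the series" means these few. Any claim that something is new, unique, unknown or untested is made for them only; others in the source may bear on it.

Compound 1 `CCOc1cc(OC)ccc1C[S+]([O-])c1ncccc1C(=O)Nc1ccncc1`: < 0.02 h (a limit)
Compound 2 `CCOc1ccc(C[S+]([O-])c2ncccc2C(=O)Nc2ccncc2)c(OCC)c1`: < 0.02 h (a limit)
Compound 3 `COc1cc(C[S+]([O-])c2ncccc2C(=O)Nc2ccncc2)cc(OC)c1OC`: 7.7 h

In an ADME assay (on this read-out lower numbers stand for a shorter-lived compound and higher numbers for a longer-lived compound), compound 1 gives < 0.02 h, which is a limit and not a number. Compound 1 therefore stands at the limit of < 0.02 h in this assay, at which 2 of the 3 values shown sit. Compound 3 is the only one of the three with a number, at 7.7 h.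

Compound 4 `COCOCCOc1cc(OC)ccc1C[S+]([O-])c1ncccc1C(=O)Nc1ccncc1` keeps the core of compound 1 and differs in one place: methoxymethoxy in place of hydrogen on a saturated chain carbon, two bonds along the chain from an oxygen on an aromatic ring. Cut one bond further out, this is ethoxy to 2-(methoxymethoxy)ethoxy.

Among the compounds with values here, the only measured step that bears on this change is a step that the two limits leave unreadable from compound 1 to compound 2. Within the data shown here, it gives no size or direction to carry over, so no step of definite size is expected in this assay. With only a limit as the starting point, the expected step is a number no lower from compound 1 to compound 4 (the limit leaves the size open). For compound 4 the estimated half-life is 0.02 h, with an expected range of 0.005 h to 0.2 h. A result reported only as a limit is the expected outcome.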

Compound 4, half-life: < 0.02 h
Compound 4 ended at the assay's limit; the forecaster's own chance of this, stated with the estimate: 75%; the middle value sits exactly at the limit.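

Compound 1 and compound 4 both end at a limit in this assay, so no step can be read between them: the limit of < 0.02 h in this assay, at which 3 of the 4 values shown sit.

The compounds shown leave open the size and direction of any difference between ethoxy and 2-(methoxymethoxy)ethoxy on the core of compound 1.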